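Swapping the benzyl substituent on the oxime ether of compound 3

This account rests on a few compounds, and the source may have more. Where it says the series, first, only, none or still open, it means among the compounds named here.

Compound 3 `FC(F)(F)c1ccc(CO/N=C/c2c(-c3ccc4ccccc4c3)nc3occn23)cc1` was tested in an assay on HepG2 cells for agonist activity at nuclear receptor subfamily 1 group I member 3 (Homo sapiens), read by a luciferase reporter, with a stated time of 23 h (on this read-out higher numbers stand for an effect only at larger amounts of compound and lower numbers for an effect already at smaller amounts), and gives 470 nM. Compound 1 `Cc1ccc(-c2nc3sccn3c2/C=N/OCc2ccc(Cl)c(Cl)c2)cc1` gives 490 nM in this assay, a number within the scatter of that of compound 3, so the two cannot be ranked. Compound 2 `Clc1ccc(CO/N=C/c2c(-c3ccc(-c4ccccc4)cc3)nc3sccn23)cc1Cl` is reported in this assay as "not active" (no number reported), with no number given. Compound 4 `Clc1ccc(CO/N=C/c2c(-c3ccc4ccccc4c3)nc3occn23)cc1Cl` is not yet measured. It differs from compound 3 in one place: 3,4-dichlorophenyl in place of 4-(trifluoromethyl)phenyl on a saturated chain carbon bound to an oxygen on an unsaturated carbon. For the measured compounds named here, no measured pair isolates this change, so the account can only note that the 3,4-dichlorophenyl group is present in both compound 1 and compound 2, one with a number and one without. For compound 4 the step of a 1.3-fold higher number from compound 3 to compound 4 (0.11 log units; within the scatter) is expected to stay within the scatter, and the estimate for compound 4 is 600 nM with a range from 200 nM to 3000 nM.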

Compound 4, half-maximal effective concentration: 370 nM
Compound 4: middle estimate off by 1.6-fold (0.21 log units), on the high side; measured number inside the range.
By their numbers in this assay, from the lowest: compounds 4, 3 and 1 (each within the scatter of the next).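

In this assay the exchange of 4-(trifluoromethyl)phenyl for 3,4-dichlorophenyl on a saturated chain carbon bound to an oxygen on an unsaturated carbon gives a 1.3-fold lower number from compound 3 to compound 4 (0.10 log units; within the scatter) and so leaves the two compounds unranked. This is the only pair shown that isolates this position, and here the two halogen-bearing phenyl groups cannot be told apart. Nothing measured here explains this result. On these data alone, whether an amine or a carboxylic acid in place of the phenyl ring keeps the effect remains open. So does whether this exchange would give the same result on the cores of compound 1 and compound 2.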